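The source may hold more compounds than are shown below. What is called first, only, known or untested is meant among the compounds shown, and "the series" means these compounds.

Working notes on an ADME assay on HepG2 cells (Homo sapiens) for cytotoxicity, read by MTT assay, with a stated time of 7 days; a higher number here means a weaker inhibitor, a lower number a stronger inhibitor. Compound 1 `CC(C)Oc1ccc(C2CC(c3ccc(O)cc3)=NN2C(=O)c2cccnc2)cc1` gives 45400 nM and compound 2 `CC(C)c1ccc(C2CC(c3ccc(O)cc3)=NN2C(=O)c2cccnc2)cc1` gives 38700 nM. Within the data shown here, compound 2 therefore stands within the scatter of the only other measured compound, and no order can be drawn between the two.

The next structure is compound 3 `Cc1cc(C)c(C2CC(c3ccc(O)cc3)=NN2C(=O)c2cccnc2)c(C)c1`, which has 2,4,6-trimethylphenyl in place of 4-isopropylphenyl on a saturated ring carbon. The two compounds have the same atoms, joined differently.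

Among the measured compounds shown here, only one measured step bears on this change: a 1.2-fold lower number from compound 1 to compound 2 (0.07 log units; within the scatter), with isopropyl in place of isopropoxy on an aromatic carbon. That step is small, but it only swaps one group for another on this aromatic ring. For the measured compounds named here, no measured compound carries 2,4,6-trimethylphenyl, so the data give no direct test of it and no basis for a direction.

In this assay, no step beyond the scatter is therefore expected, and the estimated change is a 1.0-fold higher number from compound 2 to compound 3 (0.01 log units; within the scatter). For compound 3 the expected value is 40000 nM. The estimated range for compound 3 runs from 20000 nM to 80000 nM.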

Compound 3, half-maximal inhibitory concentration: 54500 nM
Beside the measured number, compound 3's estimate is 1.4-fold (0.13 log units) below it; low and high end bracket the measured number.
By their numbers in this assay, from the lowest: compounds 2, 1 and 3 (each within the scatter of the next).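

On the saturated ring carbon, this assay now gives a reading for replacing the whole aromatic substituent rather than only the group it carries: 2,4,6-trimethylphenyl in place of 4-isopropylphenyl gives a 1.4-fold higher number from compound 2 to compound 3 (0.15 log units; within the scatter) and 2,4,6-trimethylphenyl in place of 4-isopropoxyphenyl gives a 1.2-fold higher number from compound 1 to compound 3 (0.08 log units; within the scatter) in this series. Among these compounds, both steps lie within the scatter, so compound 1, compound 2 and compound 3 cannot be put in any order, even though the three methyl groups of compound 3 replace the single isopropyl or isopropoxy group of the other two. No supporting measurement is available to account for this result.

On these data alone, all three compounds carry only a carbon-ring aromatic group at this position, so it remains open whether an amine or a carboxylic acid on that ring, or a longer chain in its place, would produce a step beyond the scatter. The 4-hydroxyphenyl group and the (pyridin-3-yl)carbonyl group are the same throughout, so these compounds say nothing about changes at either one.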